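Working notes: replacing 3-(trifluoromethyl)phenyl in compound 2

A few compounds are considered here, and "the series" means these few. Any claim that something is new, unique, unknown or untested is made for them only; others in the source may bear on it.

- Compound 1 (`COc1ccc(Nc2ncnc3cc(OC)c(OCCCSc4nc5ccccc5o4)cc23)cc1`) gives 13100 nM in a functional assay on MCF7 cells (Homo sapiens) for cytotoxicity, read by MTT assay, with a stated time of 24 h (a higher number here means a weaker inhibitor, a lower number a stronger inhibitor), as the read-out
- Compound 2 (`CCCCc1nc(Cl)c(C=O)n1CCCOc1cc2c(Nc3cccc(C(F)(F)F)c3)ncnc2cc1OC`) gives 3510 nM in this assay as the read-out

Of these two numbers, compound 2 has the lower, and its gap to compound 1 lies beyond the usual scatter. Compound 3 (`CCCCc1nc(Cl)c(C=O)n1CCCOc1cc2c(Nc3ccc(OC)cc3)ncnc2cc1OC`) is the next to be read. It has 4-methoxyphenyl in place of 3-(trifluoromethyl)phenyl on a nitrogen on an aromatic ring. For the measured compounds named here, no measured pair isolates this change, so its size in this assay cannot be read directly from the series. Going by the values given here, the only guide is thin: compound 1 also carries 4-methoxyphenyl and gives 13100 nM in this read-out, but it differs from compound 3 elsewhere as well. A modest rise in the number is therefore expected, close to the edge of the scatter, and no more than that can be argued from two compounds. The expected change is a 1.6-fold higher number from compound 2 to compound 3 (0.20 log units; within the scatter) (an estimate, with the number moving upward). Compound 3 is estimated at 5500 nM (expected range 1800 nM to 16000 nM).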

Compound 3, half-maximal inhibitory concentration: 14000 nM
For compound 3 the middle estimate is 2.5-fold (0.41 log units) below the measured one; low and high end bracket the measured number.
By their numbers in this assay, from the lowest: compound 2; then compounds 1 and 3 (each within the scatter of the next).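

In this assay the exchange of 3-(trifluoromethyl)phenyl for 4-methoxyphenyl on a nitrogen on an aromatic ring now has a direct reading, with a 4.0-fold higher number from compound 2 to compound 3 (0.60 log units; beyond the scatter) as the step beyond the scatter, so this position affects the cytotoxicity read-out while the 2-butyl-4-chloro-5-formyl-1H-imidazol-1-yl chain end is held fixed. With 4-methoxyphenyl held fixed instead, the exchange of (1,3-benzoxazol-2-yl)sulfanyl for 2-butyl-4-chloro-5-formyl-1H-imidazol-1-yl on the saturated chain carbon gives a 1.1-fold higher number from compound 1 to compound 3 (0.03 log units; within the scatter) as a step within the scatter, so this pair shows no resolved effect of the chain end. Nothing at hand explains the response at the nitrogen position.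

For the compounds shown here, the single pair at the nitrogen changes both the substituent and its place on the ring, and 3-methoxyphenyl or 4-(trifluoromethyl)phenyl would be needed to separate the two. Going by these compounds, it also remains open whether the two chain ends stay indistinguishable when 3-(trifluoromethyl)phenyl replaces 4-methoxyphenyl, which would take the (1,3-benzoxazol-2-yl)sulfanyl chain end paired with 3-(trifluoromethyl)phenyl.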